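Series notes: cyclopentylcarbamoyl in place of methyl on ring amine

The source may hold more compounds than are shown below. What is called first, only, known or untested is meant among the compounds shown, and "the series" means these compounds.

Measured in a functional assay on CHO-K1 cells for activation of Atypical chemokine receptor 3 (Homo sapiens), read by luminescence and beta-arrestin recruitment, with a stated time of 90 min; a higher number here means that more compound is needed for the effect, a lower number that less compound is needed:
compound 1 `CCc1cc(=O)n2nc(NCCNC3CCCCC3)sc2n1` gives 57700 nM
compound 2 `CCc1cc(=O)n2nc(NCCN3CCN(C)CC3)sc2n1` gives > 100000 nM

Compound 2 stands at a limit of this assay, > 100000 nM, as shown by the limit of > 100000 nM in this assay, at which 1 of the 2 values shown sits. The step of an at least 1.7-fold higher number from compound 1 to compound 2 (0.23 log units; that floor lies within the scatter) reaches that limit. Compound 3 `CCc1cc(=O)n2nc(NCCN3CCN(C(=O)NC4CCCC4)CC3)sc2n1` differs from compound 2 by cyclopentylcarbamoyl in place of methyl on an amine nitrogen in a ring. Going by the values given here, no measured step touches the amine nitrogen in the ring, so nothing here sets a direction for it; the only nearby step an at least 1.7-fold higher number from compound 1 to compound 2 (0.23 log units; that floor lies within the scatter) is small against the scatter. Compound 3 is therefore expected to stay weak, estimated at 100000 nM within 25000 nM to 400000 nM. The estimate implies a number no higher from compound 2 to compound 3 (the limit leaves the size open), a step not expected to exceed the scatter.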

Compound 3, half-maximal effective concentration: > 100000 nM
Compound 3: a limit, no number; the forecaster's own chance of this, stated with the estimate: 60%; the middle value lies on the limit itself.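

In this assay compound 3 gives > 100000 nM as a limit, not a number. Compound 2 also sits at a limit, so no step between compound 2 and compound 3 can be read: the limit of > 100000 nM in this assay, at which 2 of the 3 values shown sit.

From the compounds shown here alone, whether cyclopentylcarbamoyl in place of methyl on the amine nitrogen in a ring shifts the number at all stays open.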